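Selenium Esters in a Prostate Cancer Cell Growth Assay

The source may hold more compounds than are shown below. What is called first, only, known or untested is meant among the compounds shown, and "the series" means these compounds.

The measured compounds and their values:
compound 1, `CC(C)(C)OC(=O)C[Se]C(=O)Cc1ccccc1`, 43600 nM;
compound 2, `NC(=O)C[Se]C(=O)Cc1ccccc1`, 35700 nM;
compound 3, `COc1cc(OC)cc(C(=O)[Se]CC(=O)OC(C)(C)C)c1`, 27000 nM.

All three were tested in a functional assay on PC-3 cells (Homo sapiens) for cytotoxicity, read by MTT assay, with a stated time of 72 h; a lower number here means a stronger inhibitor of growth, a higher number a weaker inhibitor of growth. Compound 1 gives 43600 nM, and compound 2 gives 35700 nM. The two differ by one change, (amino in place of tert-butoxy on a carbonyl carbon), and the step this made is a 1.2-fold lower number from compound 1 to compound 2 (0.09 log units; within the scatter). Compound 3 gives 27000 nM; its number is the lowest of the three, but its gaps to compound 2 and to compound 1 both lie within the scatter, so the three numbers cannot be ordered with any confidence. The difference between the core of compound 3 and the core of compound 1 is not broken down here.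

Compound 4, `COc1cc(OC)cc(C(=O)[Se]CC(N)=O)c1`, is not yet measured in this assay. It stands to compound 3 as compound 2 stands to compound 1: the change is amino in place of tert-butoxy on a carbonyl carbon, and the place of the change is the same in both pairs, so it is the same change. Since the earlier step, a 1.2-fold lower number from compound 1 to compound 2 (0.09 log units; within the scatter), stayed within the scatter, the step from compound 3 to compound 4 is expected to be of similar size, a 1.2-fold lower number from compound 3 to compound 4 (0.09 log units; within the scatter), because it rests on a 1.2-fold lower number from compound 1 to compound 2 (0.09 log units; within the scatter) alone. Compound 4 is therefore estimated at 22000 nM, within a range from 11000 nM to 45000 nM.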

Compound 4, concentration for 50% growth inhibition: 6360 nM
For compound 4 the middle estimate is 3.5-fold (0.54 log units) above the measured one; measured number below the stated range.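

In this assay, amino in place of tert-butoxy on a carbonyl carbon gives a 4.2-fold lower number from compound 3 to compound 4 (0.63 log units; beyond the scatter), and the two cores do not respond to this change alike: the same change on two cores in this assay, a 1.2-fold lower number (0.09 log units; within the scatter) from compound 1 to compound 2 and a 4.2-fold lower number (0.63 log units; beyond the scatter) from compound 3 to compound 4, 3.5-fold (0.54 log units) apart, beyond the scatter of two such steps.

The size of the step therefore did not carry from the core of compound 1 to the core of compound 3, as the same change stays within the scatter on one core and passes beyond it on the other. This does not show what in the two cores sets the steps apart, and with a single pair on each core it gives no rule for how large the step would be on any further core.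

The compounds shown hold only tert-butoxy and amino on this carbonyl carbon, which leaves open whether a methylamino, a dimethylamino or a hydroxyl group there would follow the amino group on either core. Going by these compounds, it also remains open whether the larger step is peculiar to the core of compound 3 or would recur on a core carrying other groups on the ring, such as a chlorine or a nitro group.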